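The source may hold more compounds than are shown below. What is called first, only, known or untested is meant among the compounds shown, and "the series" means these compounds.

Of the compounds shown here, three built on one shared core have been tested in an ADME assay on HUVEC cells (Homo sapiens) for antiproliferative activity, read by MTT assay, with a stated time of 48 h; on this read-out higher numbers stand for weaker inhibition and lower numbers for stronger inhibition. Compound 1 `N#CC1=C(N)Oc2c(c3nc4ccccc4nc3c3ccccc23)C12C(=O)N(Cc1cnnn1-c1cccc(S(N)(=O)=O)c1)c1ccccc12` gives 38600 nM in this assay. Compound 2 `Cc1ccc(Cl)cc1-n1nncc1CN1C(=O)C2(C(C#N)=C(N)Oc3c2c2nc4ccccc4nc2c2ccccc32)c2ccccc21` reaches only a limit of this assay, > 50000 nM. The swap of 5-chloro-2-methylphenyl in place of 3-sulfamoylphenyl on an aromatic nitrogen produces an at least 1.2-fold higher number from compound 1 to compound 2 (0.11 log units; that floor lies within the scatter). Compound 3 `N#CC1=C(N)Oc2c(N)cc3nc4ccccc4nc3c2C12C(=O)N(Cc1cnnn1-c1cccc(Br)c1)c1ccccc12` also stands only at a limit of this assay, > 50000 nM. Compound 3 thus sits at the weak end of what the numbers can show, with no measurable value of its own.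

Compound 4 `CCc1cccc(C)c1-n1nncc1CN1C(=O)C2(C(C#N)=C(N)Oc3c(N)cc4nc5ccccc5nc4c32)c2ccccc21` has not been measured. It differs from compound 3 in one place: 2-ethyl-6-methylphenyl in place of 3-bromophenyl on an aromatic nitrogen. For the measured compounds named here, the only measured step of the same kind, the exchange of one aryl group on that aromatic nitrogen between compound 1 and compound 2, stayed within the scatter, and the limit of > 50000 nM in this assay, at which 2 of the 3 values shown sit, shows how little room remains on the weak side. No step beyond the scatter is therefore expected in this assay. Compound 4 is expected to give 50000 nM, between 20000 nM and 120000 nM. The step from compound 3 is estimated as a number no higher from compound 3 to compound 4 (the limit leaves the size open), most likely again reported only as a limit.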

Compound 4, half-maximal inhibitory concentration: > 50000 nM
Compound 4 ended at the assay's limit; the forecaster's own chance of this, stated with the estimate: 75%; the middle value lies on the limit itself.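

Compound 3 and compound 4 both stand only at a limit in this assay, so no step between them can be read: the limit of > 50000 nM in this assay, at which 3 of the 4 values shown sit.

The compounds shown leave open what real values compound 3 and compound 4 have, and whether 2-ethyl-6-methylphenyl and 3-bromophenyl differ in effect at all.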